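Methoxy-to-hydrogen step and cytotoxicity across two cores

This account rests on a few compounds, and the source may have more. Where it says the series, first, only, none or still open, it means among the compounds named here.

Measured compounds:
compound 1 `COc1ccc(/C=C/C(=O)CC(=O)/C=C/c2ccc(O)c(OC)c2)cc1`, 79000 nM
compound 2 `COc1ccc(/C=C/C(=O)CC(=O)/C=C/c2ccc(O)cc2)cc1`, 400000 nM
compound 3 `COc1cc(/C=C/C(=O)CC(=O)/C=C/c2ccc(O)cc2)ccc1OC(=O)c1ccccc1`, 370000 nM

In an ADME assay on HEK293 cells (Homo sapiens) for cytotoxicity, read by resazurin assay, with a stated time of 16 h (a lower number here means that less compound is needed, a higher number that more compound is needed for the effect), compound 1 gives 79000 nM, and the step of a 5.1-fold higher number from compound 1 to compound 2 (0.70 log units; beyond the scatter) follows the change (hydrogen in place of methoxy on an aromatic carbon). Compound 3 gives 370000 nM, which lies within the scatter of compound 2. How the core of compound 3 differs from that of compound 1 is not broken down here.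

Compound 4 `O=C(/C=C/c1ccc(O)cc1)CC(=O)/C=C/c1ccc(OC(=O)c2ccccc2)cc1` is not yet measured. The change from compound 3 is hydrogen in place of methoxy on an aromatic carbon. In compound 1 the leaving methoxy sits ortho to a hydroxy group; in compound 3 it sits ortho to a benzoyloxy group, so this is the same kind of change, not the same change. Going by the values given here, only one earlier instance exists, and it sits on a different core, so the expectation is weak. A step of similar direction and size is expected, a 2.7-fold higher number from compound 3 to compound 4 (0.43 log units; beyond the scatter), resting on a 5.1-fold higher number from compound 1 to compound 2 (0.70 log units; beyond the scatter). For compound 4 in this assay the estimate is 1000000 nM, expected to fall between 400000 nM and 3000000 nM.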

Compound 4, half-maximal effective concentration: 270000 nM
Compound 4: the middle estimate sits 3.7-fold (0.57 log units) above what was measured; the measured number lies below the stated range.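

In this assay the methoxy-to-hydrogen change does not carry over from one core to the other: the same change on two cores in this assay, a 5.1-fold higher number (0.70 log units; beyond the scatter) from compound 1 to compound 2 and a 1.4-fold lower number (0.14 log units; within the scatter) from compound 3 to compound 4, 6.9-fold (0.84 log units) apart, beyond the scatter of two such steps

On the core of compound 3 the change gives a 1.4-fold lower number from compound 3 to compound 4 (0.14 log units; within the scatter), and benzoyl in place of methyl on the oxygen on the aromatic ring gives a 1.5-fold lower number from compound 2 to compound 4 (0.17 log units; within the scatter), so neither step separates the compounds involved. Going by these compounds alone, with only one pair on each core, the step from compound 1 to compound 2 cannot serve as a general size for this change, but these data do not show which feature of the cores sets the two steps apart, or which step is more typical.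

From the compounds shown here alone, it remains open whether a further methoxy-to-hydrogen pair on another core would resemble the first step or the second. Also open, going by these compounds, is how this assay would read with an amine or a carboxylic acid in place of the benzoyl group.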